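The compounds below may be only part of what the source reports. "The series", "measured", "known", "first", "only" and "open" are said of these compounds alone.

Measured so far in a functional assay on PC-3 cells (Homo sapiens) for antiproliferative activity, read by MTT assay, tested at 5 uM; on this read-out higher numbers stand for a stronger effect at the one concentration tested and lower numbers for a weaker effect:
compound 1, `COc1cc(C2=NN(C(C)=O)C(c3ccccc3C(F)(F)F)O2)cc(OC)c1OC`, gives 15.2%
compound 2, `COc1cccc(/C=N/NC(=O)c2cc(OC)c(OC)c(OC)c2)c1OC`, gives 67%

Compound 1 stands lower than compound 2 in this assay, and the gap between them is beyond the usual scatter of this kind of measurement; compound 1 thus shows the weaker effect of the two. Compound 3, `COc1cc(C2=NN(C(C)=O)C(c3ccc(Cl)c([N+](=O)[O-])c3)O2)cc(OC)c1OC`, shares the core of compound 1 and differs from it in one place: 4-chloro-3-nitrophenyl in place of 2-(trifluoromethyl)phenyl on a saturated ring carbon. Among the compounds with values here, no step between two measured compounds follows this kind of exchange, so the direction of the change cannot be read from the numbers in hand. The account therefore rests on compound 1 alone. In this assay compound 3 is estimated to give 22%, with a range from 5% to 45%. This estimate means a step of a number 6.8 percentage points higher from compound 1 to compound 3 (within the scatter) that is expected to stay within, or only slightly beyond, the scatter.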

Compound 3, a percentage reported as inhibition, at one concentration (the size of the read-out at that concentration, not a potency): 61.4%
For compound 3 the middle estimate is 39.4 percentage points below the measured one; measured number above the stated range.
By their numbers in this assay, from the lowest: compound 1; then compounds 3 and 2 (each within the scatter of the next).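

On the saturated ring carbon of the shared core, the group carried there matters strongly in this assay: 4-chloro-3-nitrophenyl in place of 2-(trifluoromethyl)phenyl means a number 46.2 percentage points higher from compound 1 to compound 3 (beyond the scatter). The two groups match in heavy-atom count and in their one six-membered aromatic ring of carbon only, so this large step comes with no change in either count, only with a different set of atoms on that ring. Nothing measured here explains why this exchange has so large an effect.

From the compounds shown here alone, the exchange removes the trifluoromethyl group and brings in chlorine and a nitro group at once, so the share of each in the step stays open. Also open, going by these compounds, is how a 4-chlorophenyl, a 3-nitrophenyl or an aminophenyl group would stand on this same carbon.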